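The compounds below may be only part of what the source reports. "The series", "measured", "known", "first", "only" and "open" are said of these compounds alone.

The measured compounds:
compound 1, `O=C(NCc1ccc(S(=O)(=O)c2cccc(C(F)(F)F)c2)cc1)c1cc2cnccc2[nH]1`, gives 8 nM in an assay for inhibition of Nicotinamide phosphoribosyltransferase (Homo sapiens), read by mass spectrometry, with stated times of 15 min and 30 min; on this read-out lower numbers stand for stronger inhibition and higher numbers for weaker inhibition.
compound 2, `O=C(NCc1ccc(S(=O)(=O)N2CCCCC2)cc1)c1cnc2nccn2c1`, gives 3 nM in this assay.
compound 3, `O=C(NCc1ccc(S(=O)(=O)c2cccc(C(F)(F)F)c2)cc1)c1cc2ccncc2o1`, gives 5 nM in this assay.

Compound 3 stands second highest of the three numbers. Its nearest neighbour is compound 1, and the step from compound 1 to compound 3 was a 1.6-fold lower number from compound 1 to compound 3 (0.20 log units; within the scatter). Compound 2 lies on the other side of compound 3, and the two numbers fall within the scatter of each other, so no order is claimed among the three.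

Compound 4, `O=C(NCc1ccc(S(=O)(=O)c2cccc(C(F)(F)F)c2)cc1)c1cnc2nccn2c1`, differs from compound 3 by a group of 9 heavy atoms (6 carbon, 3 nitrogen; one five-membered aromatic ring with 2 hetero atoms, one six-membered aromatic ring with 2 hetero atoms) in place of a group of 9 heavy atoms (7 carbon, 1 nitrogen, 1 oxygen; one five-membered aromatic ring with 1 hetero atom, one six-membered aromatic ring with 1 hetero atom), on a carbonyl carbon. Going by the values given here, the group that enters is the one compound 2 already carries on its carbonyl carbon, while the rest of compound 4 is that of compound 3 and compound 1. Two measured facts bear on the step. The exchange of the group on the carbonyl carbon from compound 1 to compound 3 moved the number only by a 1.6-fold lower number from compound 1 to compound 3 (0.20 log units; within the scatter), within the scatter. Compound 2, carrying the entering group on a different remainder, gives 3 nM, within the scatter of the value of compound 3. No step beyond the scatter is therefore expected in this assay. Compound 4 is expected to give 4 nM, with a range from 1.5 nM to 12 nM. The step from compound 3 to compound 4 is thus estimated at a 1.3-fold lower number from compound 3 to compound 4 (0.10 log units; within the scatter).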

Compound 4, half-maximal inhibitory concentration: 1 nM
Beside the measured number, compound 4's estimate is 4.0-fold (0.60 log units) above it; the measured number lies below the stated range.
By their numbers in this assay, from the lowest: compound 4; then compounds 2, 3 and 1 (each within the scatter of the next, the first and the last beyond it).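

On the carbonyl carbon, where the earlier exchange of groups moved the number little (a 1.6-fold lower number from compound 1 to compound 3 (0.20 log units; within the scatter)), the group that enters in compound 4 gives a step beyond the scatter in this assay, both against the group of compound 3 (a 5.0-fold lower number from compound 3 to compound 4 (0.70 log units; beyond the scatter)) and against the group of compound 1 (an 8.0-fold lower number from compound 1 to compound 4 (0.90 log units; beyond the scatter)), so the choice of group at this place does register in the read-out. Going by these compounds alone, the sulfonyl sulfur, for which the earlier compounds held no comparison in one place, now has one: 3-(trifluoromethyl)phenyl in place of piperidin-1-yl gives a step of its own (a 3.0-fold lower number from compound 2 to compound 4 (0.48 log units; beyond the scatter)). Compound 4 is thereby set apart from all three other compounds, with each of its steps beyond the scatter, though all remain modest in size.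

Going by these compounds, whether a morpholin-4-yl group or an unsubstituted phenyl on the sulfonyl sulfur would follow either of the two groups seen there remains open, as does whether the step on the carbonyl carbon would hold with piperidin-1-yl on the sulfur. What lies behind these steps also stays open, since no measurement bearing on them is given.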